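A few compounds are considered here, and "the series" means these few. Any claim that something is new, unique, unknown or untested is made for them only; others in the source may bear on it.

Two compounds have been measured so far in a functional assay on HL-60 cells (Homo sapiens) for inhibition (a lower number here means a stronger inhibitor, a higher number a weaker inhibitor), as follows:

Compound 1 `OC[C@H]1OC(n2cnc3c(-c4ccccn4)ncnc32)[C@H](O)[C@@H]1O` gives 5600 nM
Compound 2 `OC[C@H]1OC(n2cnc3c(-c4ccc(O)cc4)ncnc32)[C@H](O)[C@@H]1O` gives 7600 nM

For the measured compounds named here, compound 2 stands within the scatter of compound 1, the only other compound with a number. Going by the values given here, the sole measured step (a 1.4-fold higher number from compound 1 to compound 2 (0.13 log units; within the scatter)) exchanged one aromatic group for another on the same carbon of the shared core. Compound 3 `Cn1cccc1-c1ncnc2c1ncn2C1O[C@H](CO)[C@@H](O)[C@H]1O` changes that carbon again, with 1-methyl-1H-pyrrol-2-yl in place of 4-hydroxyphenyl on an aromatic carbon. Among the compounds with values here, only that one step bears on this change, and it stayed within the scatter. Within the data shown here, no compound with a five-membered aromatic ring has been measured, so the data give no direction and the range must stay wide. No step beyond the scatter is therefore expected in this assay for this exchange, though a larger one cannot be excluded. The expected change is small on this estimate (a 1.4-fold lower number from compound 2 to compound 3 (0.14 log units; within the scatter)). Compound 3 is expected at 5500 nM with an estimated lower end of 1500 nM and an upper end of 18000 nM (both are estimates).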

Compound 3, half-maximal inhibitory concentration: 15700 nM
For compound 3 the middle estimate is 2.9-fold (0.46 log units) below the measured one; the range from low to high includes it.
By their numbers in this assay, from the lowest: compounds 1 and 2 (each within the scatter of the next); then compound 3.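

In this assay, the group on this aromatic carbon now proves able to move the number beyond the scatter: 1-methyl-1H-pyrrol-2-yl in place of 4-hydroxyphenyl gave a 2.1-fold higher number from compound 2 to compound 3 (0.32 log units; beyond the scatter), and in place of pyridin-2-yl it gave a 2.8-fold higher number from compound 1 to compound 3 (0.45 log units; beyond the scatter), whereas the earlier exchange between those two groups had stayed within it (a 1.4-fold higher number from compound 1 to compound 2 (0.13 log units; within the scatter)). Compound 3, the only one shown with a five-membered aromatic ring, is thus the weakest inhibitor of the three, although both of its steps are modest and this single compound sets no pattern for such rings. Nothing at hand accounts for this difference.

The exchange replaces the ring, its hetero atom and the methyl group at once, and the compounds shown do not separate what each of these contributes. As far as these compounds go, it also remains open how this carbon would respond to the unmethylated pyrrol-2-yl, thiophen-2-yl, an amine, a carboxylic acid or a longer alkyl chain, and whether any group on it could give a clearly lower number than compound 1 does.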